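From phenylcarbamoyl to methyl(1,3-oxazol-2-yl)amino on a shared core

This account rests on a few compounds, and the source may have more. Where it says the series, first, only, none or still open, it means among the compounds named here.

compound 1 `O=C(Nc1ccccc1)c1cnc(NCc2c(F)ccc3c2CCO3)n2cnnc12`: 4.1
compound 2 `Cc1ncccc1-c1cnc(NCc2c(F)ccc3c2CCO3)c2nn(CC#N)c(=O)n12`: 2.2

For the measured compounds named here, both compounds have been measured in a physicochemical assay for lipophilicity, using the shake flask method, in phosphate buffer, measured as octanol-water partition, with a stated time of 30 min, at pH 7.4; on this read-out higher numbers stand for higher lipophilicity and lower numbers for lower lipophilicity. Compound 1, at 4.1, stands highest of the two, and the gap down to compound 2, at 2.2, is beyond the usual scatter. Compound 3 `CN(c1ncco1)c1cnc(NCc2c(F)ccc3c2CCO3)n2cnnc12` has not yet been measured. It keeps the core of compound 1 but carries methyl(1,3-oxazol-2-yl)amino in place of phenylcarbamoyl on an aromatic carbon. Going by the values given here, no measured pair differs in one place only, so the data show no direct precedent for this change. Compound 2, which also lacks phenylcarbamoyl, gives 2.2, but it differs from compound 1 in several places and is only a loose guide. A downward move in this assay, beyond the scatter, is expected: the estimated step is a number 0.90 log units lower from compound 1 to compound 3 (beyond the scatter). For compound 3 the estimate is 3.2, with an expected range from 2.6 to 3.8.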

Compound 3, distribution coefficient: 2.1
Estimate against measurement, compound 3: 1.10 log units above, outside the stated range (below it).
By their numbers in this assay, from the lowest: compounds 3 and 2 (each within the scatter of the next); then compound 1.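

In this assay, placing methyl(1,3-oxazol-2-yl)amino in place of phenylcarbamoyl on an aromatic carbon of the shared core gives a number 2.00 log units lower from compound 1 to compound 3 (beyond the scatter) as a large step from a change in one place only, so the read-out clearly depends on which of these two groups sits here. The swap changes several things at once: a six-membered aromatic ring of carbon only gives way to a five-membered aromatic ring with 2 hetero atoms, and 1 hydrogen-bond donor gives way to 0 hydrogen-bond donors. Nothing available explains the step or ties it to any one of these differences.

Going by these compounds, how much of the step belongs to the methyl group alone remains open. Also open, on these data alone, is how a simple amine or a carboxylic acid on this aromatic carbon would read in this assay.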